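Cytotoxicity series: iodo replacing trifluoromethyl on the aryl ring

A few compounds are considered here, and "the series" means these few. Any claim that something is new, unique, unknown or untested is made for them only; others in the source may bear on it.

Two compounds of the series have a number in an ADME assay on MT4 cells (Homo sapiens) for cytotoxicity, read by MTT assay; a lower number here means that less compound is tolerated, a higher number that more compound is tolerated. Compound 1 `O=[N+]([O-])c1cccc(NC(=S)OCCc2ccccn2)c1` gives 100000 nM in this assay. Compound 2 `FC(F)(F)c1ccc(NC(=S)OCCc2ccccn2)cc1` gives 50000 nM in this assay, the lowest of the two numbers; its nearest neighbour is compound 1, whose number lies within the scatter of that of compound 2, so the two compounds cannot be told apart on these data.

Compound 3 `S=C(Nc1ccc(I)cc1)OCCc1ccccn1` is not yet measured. It differs from compound 2 by iodo in place of trifluoromethyl on an aromatic carbon. Among the compounds with values here, no pair of measured compounds shows what this change does in this assay, so the expectation rests on compound 2 alone. The step of no change at the digits printed from compound 2 to compound 3 (within the scatter) is expected to stay within the scatter, with no clear direction. Compound 3 is therefore estimated at 50000 nM in this assay, with a range from 20000 nM to 130000 nM.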

Compound 3, half-maximal cytotoxic concentration: 34000 nM
Compound 3: the middle estimate sits 1.5-fold (0.17 log units) above what was measured; the range from low to high includes it.
By their numbers in this assay, from the lowest: compounds 3, 2 and 1 (each within the scatter of the next, the first and the last beyond it).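

In this assay, iodo in place of trifluoromethyl on an aromatic carbon, para to a large group, gives a 1.5-fold lower number from compound 2 to compound 3 (0.17 log units; within the scatter). Within the data shown here, this pair gives the first one-place reading at this position, and on this reading the two groups cannot be told apart, although the group that leaves has 4 heavy atoms and the one that enters has 1. Nothing available bears on why the two groups read alike.

Still open is how this assay responds at this position to a group of a different kind, such as an amine or a carboxylic acid, neither of which appears among these compounds. A single pair also cannot show whether iodo in place of trifluoromethyl would read the same way on another aromatic carbon.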